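Trifluoromethyl for methoxy on the second arylidene

The source may hold more compounds than are shown below. What is called first, only, known or untested is meant among the compounds shown, and "the series" means these compounds.

Measured compounds:
compound 1 `C=CCn1c(=O)/c(=C\c2cccc(Cl)c2Cl)[nH]c(=O)/c1=C\c1ccccc1OC`: 2300 nM
compound 2 `C=CCn1c(=O)/c(=C\c2ccccc2OC)[nH]c(=O)/c1=C\c1ccccc1OC`: 22400 nM

Among the measured compounds shown here, in a functional assay on A549 cells (Homo sapiens) for cytotoxicity, read by CCK-8 assay, with a stated time of 72 h (a lower number here means a stronger inhibitor, a higher number a weaker inhibitor), compound 2 stands at the higher of the two numbers; the only step among them, a 9.7-fold higher number from compound 1 to compound 2 (0.99 log units; beyond the scatter), changed the same arylidene ring. Compound 3 `C=CCn1c(=O)/c(=C\c2ccccc2C(F)(F)F)[nH]c(=O)/c1=C\c1ccccc1OC` differs from compound 2 by trifluoromethyl in place of methoxy on an aromatic carbon. For the measured compounds named here, only that one step bears on this, and it shows that swapping the ring bearing a methoxy for one bearing halogens gave a lower number; with three fluorines entering, a modest lowering is expected, a 3.2-fold lower number from compound 2 to compound 3 (0.51 log units; beyond the scatter). Compound 3 is therefore estimated at 7000 nM, within 2000 nM to 22000 nM.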

Compound 3, half-maximal inhibitory concentration: 7000 nM
The estimate for compound 3 equals the measured number at the digits printed, within the range that was stated.
By their numbers in this assay, from the lowest: compound 1; then compound 3; then compound 2.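

Trifluoromethyl in place of methoxy on this aromatic carbon gives a 3.2-fold lower number from compound 2 to compound 3 (0.51 log units; beyond the scatter) in this assay, so a change at this single ring place, with no chlorine involved, already lowers the number. The 2-(trifluoromethyl)phenyl ring does not match the 2,3-dichlorophenyl ring, with a 3.0-fold higher number from compound 1 to compound 3 (0.48 log units; beyond the scatter) remaining between them. Nothing measured here accounts for this order. The compounds shown leave open how an amine or a carboxylic acid at this place would read, and whether the step holds when the other arylidene ring is changed.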